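Benzyloxy for Phenyl on a Baseline of Limits

This account rests on a few compounds, and the source may have more. Where it says the series, first, only, none or still open, it means among the compounds named here.

Compound 1 `O=C1c2ccccc2N(Cc2ccccc2)S(=O)(=O)N1Cc1ccccc1` is the starting point. In a functional assay on HEL cells (Homo sapiens) for inhibition (on this read-out lower numbers stand for higher toxicity in this test and higher numbers for lower toxicity in this test), compound 1 gives > 200000 nM, which is a limit of the assay rather than a measured number. Compound 2 `O=C1c2ccccc2N(Cc2ccc(Cl)c(Cl)c2)S(=O)(=O)N1Cc1ccccc1` carries 3,4-dichlorophenyl in place of phenyl on a saturated chain carbon bound to a sulfonamide nitrogen in a ring. In this assay compound 2 gives > 200000 nM, again a limit of the assay. The step that the two limits leave unreadable from compound 1 to compound 2 therefore cannot be read in either direction. Compound 3 `O=C1c2ccccc2N(Cc2ccccc2)S(=O)(=O)N1COCc1ccccc1` differs from compound 1 by benzyloxy in place of phenyl on a saturated chain carbon bound to an amide-type nitrogen in a ring. Going by the values given here, no measured step touches this position: the only measured comparison, from compound 1 to compound 2, changes the group on the carbon bound to the sulfonamide nitrogen, not the one bound to the amide-type nitrogen, and it is unreadable in any case. The whole of the evidence is the limit of > 200000 nM in this assay, at which 2 of the 2 values shown sit. On that footing the expected step that the limit leaves unreadable from compound 1 to compound 3 is none beyond the scatter. Compound 3 is accordingly estimated at 250000 nM in this assay, within 120000 nM to 600000 nM, most probably reported once more as a limit.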

Compound 3, half-maximal cytotoxic concentration: > 98000 nM
Compound 3 gave a limit, no number; the forecaster's own chance of this, stated with the estimate: 85%; the middle value is on the limit's open side.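

Going by these compounds alone, compound 3, like compound 1, gives only a limit of the assay, so no step between compound 1 and compound 3 can be read. What the compounds shown leave open is whether benzyloxy in place of phenyl at this position changes the result in this assay at all, and what actual value any of them would give.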